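A Pyridine for Phenyl on the Sulfonyl Group

The source may report more compounds than this note shows. Statements on the series, on what has been measured and on what is new or still open speak of the compounds shown alone.

Measured so far:
Compound 1, `CC(C)(C)c1ccc(CN(Cc2cccc(CCC(=O)O)c2)S(=O)(=O)c2ccccc2)cc1`, gives 0.2 nM in a functional assay on HEK293 cells for agonist activity at prostaglandin E2 receptor EP2 subtype (Rattus norvegicus), read by cAMP accumulation; a lower number here means that less compound is needed, a higher number that more compound is needed for the effect.
Compound 2, `Cn1ccnc1CS(=O)(=O)N(Cc1ccc(C(C)(C)C)cc1)Cc1cccc(OCC(=O)O)c1`, gives 58 nM in this assay.

Of these two numbers compound 1 shows the lower one, and its gap to compound 2 lies beyond the usual scatter. Compound 3, `CC(C)(C)c1ccc(CN(Cc2cccc(CCC(=O)O)c2)S(=O)(=O)c2ccccn2)cc1`, differs from compound 1 in one place: pyridin-2-yl in place of phenyl on a sulfonyl sulfur. Among the measured compounds shown here, no measured pair shares this single change, so the only guide is that compound 1 already needs very little material in this assay. A step of modest size from compound 1 to compound 3 is expected, a 2.5-fold higher number from compound 1 to compound 3 (0.40 log units; beyond the scatter), probably towards a somewhat higher number, possibly not beyond the scatter. Compound 3 is estimated at 0.5 nM, with a range from 0.1 nM to 3 nM.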

Compound 3, half-maximal effective concentration: 2.3 nM
For compound 3 the middle estimate is 4.6-fold (0.66 log units) below the measured one, and the stated range covers the measured number.
By their numbers in this assay, from the lowest: compound 1; then compound 3; then compound 2.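

Replacing phenyl with pyridin-2-yl on the sulfonyl sulfur keeps the ring size and adds one nitrogen, yet it gives a 12-fold higher number from compound 1 to compound 3 (1.06 log units; beyond the scatter) in this assay. This position therefore responds clearly to a change of a single ring atom. No measurement at hand explains the size of this step.

On these data alone, it remains open whether any ring nitrogen at this position gives a similar step or whether the result is specific to pyridin-2-yl. Pyridin-3-yl and pyridin-4-yl on the same sulfur would test this.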